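The source may hold more compounds than are shown below. What is called first, only, known or untested is meant among the compounds shown, and "the series" means these compounds.

Three compounds share one core, each built on the same spirocyclic lactone and piperidine bearing a benzyl group. Compound 1 `COc1ccc(-c2csc3c2CC(=O)OC32CCN(Cc3ccccc3)CC2)cc1` carries a methoxyphenyl, and in an assay on membranes from brain for displacement of a labelled ligand from Sigma non-opioid intracellular receptor 1 (Cavia porcellus), read by scintillation counting, with a stated time of 120 min (on this read-out lower numbers stand for stronger inhibition and higher numbers for weaker inhibition), compound 1 gives 43 nM. Compound 2 `O=C1OC2(CCN(Cc3ccccc3)CC2)c2csc(-c3ccccc3)c21` gives 11 nM in this assay. Compound 3 `O=C1OC2(CCN(Cc3ccccc3)CC2)c2c1csc2-c1ccccc1` gives 483 nM, the highest of the three numbers: its gap to compound 1 and its larger gap to compound 2 both lie beyond the usual scatter. Compound 4 `O=C1OC2(CCN(Cc3ccccc3)CC2)c2c(-c3ccccc3)sc(-c3ccccc3)c21` differs from compound 3 by phenyl in place of hydrogen on an aromatic carbon. Within the data shown here, no two measured compounds differ in only one place, so no direct step is available. Compound 4 is nonetheless expected to move toward lower numbers, with an estimated step of a 9.7-fold lower number from compound 3 to compound 4 (0.98 log units; beyond the scatter) and an estimated value of 50 nM, in the range 10 nM to 250 nM.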

Compound 4, inhibition constant: 87 nM
For compound 4 the middle estimate is 1.7-fold (0.24 log units) below the measured one; the range from low to high includes it.
By their numbers in this assay, from the lowest: compound 2; then compound 1; then compound 4; then compound 3.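

Phenyl in place of hydrogen on an aromatic carbon gives a 5.6-fold lower number from compound 3 to compound 4 (0.74 log units; beyond the scatter) in this assay, but the same kind of change gives a 7.9-fold higher number from compound 2 to compound 4 (0.90 log units; beyond the scatter) and so moves the other way. The effect of adding a phenyl therefore depends on which phenyl the compound already carries. Nothing available explains this difference. Still open, as far as these compounds go, is how a smaller group such as methyl, or an amine, would compare with phenyl next to the ring sulfur. Also open, from the compounds shown here alone, is whether any such group would bring compound 3 as low as compound 2.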